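A few compounds are considered here, and "the series" means these few. Any claim that something is new, unique, unknown or untested is made for them only; others in the source may bear on it.

Of the compounds shown here, two of a shared core have been tested in an ADME assay on RD cells (Homo sapiens) for cytotoxicity; on this read-out lower numbers stand for higher toxicity in this test and higher numbers for lower toxicity in this test. Compound 1 `O=C1Nc2ccccc2/C1=N/NC(=S)N1CCCCC1` is one of them. In this assay compound 1 reaches only a limit, > 25000 nM, so no number is known for it. Compound 2 `O=C1Nc2ccc(Br)cc2/C1=N/NC(=S)Nc1ccccc1` is the other. In this assay compound 2 likewise reaches only a limit, > 25000 nM. Both values therefore sit at the same point, as the evidence makes plain: the limit of > 25000 nM in this assay, at which 2 of the 2 values shown sit. Among the compounds with values here, no step between the two measured compounds is recorded, so their pair shows only two limits.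

Compound 3 `O=C1Nc2ccc(OC(F)(F)F)cc2/C1=N/NC(=S)Nc1ccccc1` is the compound yet to be tested. It differs from compound 2 in one place: trifluoromethoxy in place of bromo on an aromatic carbon. Since compound 2 shows only a limit, no step beyond the scatter is expected here, and compound 3 is estimated at 30000 nM in this assay, within 12000 nM to 90000 nM. The step that the limit leaves unreadable from compound 2 to compound 3 that this estimate implies is expected to stay within the scatter.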

Compound 3, half-maximal cytotoxic concentration: > 25000 nM
Compound 3: no number, only a limit (the forecaster's own chance of this, stated with the estimate: 75%); the middle value is on the limit's open side.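

Within the data shown here, compound 2 and compound 3 both give only a limit, so no step between them can be read for trifluoromethoxy in place of bromo: the limit of > 25000 nM in this assay, at which 3 of the 3 values shown sit. The compounds shown leave open what number any of them would actually reach in this assay, and whether the shared core can show cytotoxicity in this test at all.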